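The source may report more compounds than this note shows. Statements on the series, on what has been measured and on what is new or still open speak of the compounds shown alone.

In a functional assay on HeLa cells (Homo sapiens) for antiproliferative activity, read by MTT assay, with a stated time of 48 h (on this read-out higher numbers stand for weaker inhibition and lower numbers for stronger inhibition), three compounds built on one shared core have been measured. Compound 1 `COc1ccccc1C(=O)Nc1nnc(SCC(=O)Nc2ccc(Br)cn2)s1` returns only a limit in this assay, > 80000 nM. Compound 2 `COc1ccccc1C(=O)Nc1nnc(SCC(=O)Nc2ccc(Cl)cn2)s1` likewise returns only a limit, > 80000 nM. Among the compounds with values here, compound 3 `O=C(CSc1nnc(NC(=O)CCl)s1)Nc1ccc(Cl)cn1` is the sole compound with a number, giving 3600 nM in this assay. The change from compound 2 to compound 3 is chloromethyl in place of 2-methoxyphenyl on a carbonyl carbon, and it brings an at least 22-fold lower number from compound 2 to compound 3 (1.34 log units; beyond the scatter). The change from compound 2 to compound 1 is bromo in place of chloro on an aromatic carbon; the resulting step that the two limits leave unreadable from compound 2 to compound 1 cannot be sized because the limit of > 80000 nM in this assay, at which 2 of the 3 values shown sit, covers both compounds. Compound 4 `O=C(CSc1nnc(NC(=O)CCl)s1)Nc1ccc(Br)cn1` carries the same change made on the core of compound 3, namely (bromo in place of chloro on an aromatic carbon); the cores of compound 3 and compound 4 differ from those of compound 2 and compound 1 by the change already described. From compound 3 to compound 4 the expected step is a 1.0-fold lower number from compound 3 to compound 4 (0.01 log units; within the scatter), which rests on the earlier pair, where the limits leave the size unreadable, and on the single heavy atom exchanged. Compound 4 is therefore estimated at 3500 nM, between 1200 nM and 10000 nM.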

Compound 4, half-maximal inhibitory concentration: 3400 nM
Estimate against measurement, compound 4: 1.0-fold (0.01 log units) above; the measured number falls inside the stated range.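

In this assay, the exchange of 5-chloropyridin-2-yl for 5-bromopyridin-2-yl on the core of compound 3 gives a 1.1-fold lower number from compound 3 to compound 4 (0.02 log units; within the scatter), so on this core the halogen exchange has no readable effect. Chloromethyl in place of 2-methoxyphenyl gives an at least 23-fold lower number from compound 1 to compound 4 (1.37 log units; beyond the scatter), so this change lowers the number beyond the scatter on both cores, and its direction carries from one to the other: the same change on two cores in this assay, an at least 22-fold lower number (1.34 log units; beyond the scatter) from compound 2 to compound 3 and an at least 23-fold lower number (1.37 log units; beyond the scatter) from compound 1 to compound 4; the limit leaves it open whether they differ. This does not show that the change has the same size on both cores, and the step between compound 2 and compound 1 cannot be read either, because the values of both compounds are limits rather than numbers: the limit of > 80000 nM in this assay, at which 2 of the 4 values shown sit.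

The compounds shown leave open whether the chlorine of the chloromethyl group matters, as a plain methyl group or a longer chain ending in chlorine on the same carbonyl carbon would show. They also leave open how a 5-fluoropyridin-2-yl group would read on either core.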